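Swapping furan-2-yl for phenoxymethyl on a carbonyl carbon

The compounds below may be only part of what the source reports. "The series", "measured", "known", "first", "only" and "open" are said of these compounds alone.

In an ADME assay on HepG2 2.2.15 cells (Homo sapiens) for cytotoxicity (on this read-out higher numbers stand for lower toxicity in this test and lower numbers for higher toxicity in this test), compound 3 `O=C(OCCc1c(-c2ccccc2Cl)c2cc(Cl)ccc2[nH]c1=O)c1ccco1` gives 98000 nM and compound 1 `CCCC(=O)OCCc1c(-c2ccccc2Cl)c2cc(Cl)ccc2[nH]c1=O` gives 52000 nM on the same scale. These two values sit level with each other, as the step (a 1.9-fold higher number from compound 1 to compound 3 (0.28 log units; within the scatter)) shows. Compound 2 `O=C(OCCc1c(-c2ccccc2Cl)c2cc(Cl)ccc2[nH]c1=O)c1cccs1` gives > 1700000 nM as a limit of the assay, not a number.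

Compound 4 `O=C(COc1ccccc1)OCCc1c(-c2ccccc2Cl)c2cc(Cl)ccc2[nH]c1=O` is still unmeasured. It carries phenoxymethyl in place of furan-2-yl on a carbonyl carbon, and the count of that change is phenoxymethyl in place of furan-2-yl on a carbonyl carbon in full. All three measured steps changed the group at this same place. Two of them are large and both involve compound 2: an at least 32-fold higher number from compound 1 to compound 2 (1.51 log units; beyond the scatter) and an at least 17-fold lower number from compound 2 to compound 3 (1.23 log units; beyond the scatter) are the moves in question. So a swap here can matter, yet the pair of compound 1 and compound 3 shows that it need not. The expected step is small, a 1.0-fold higher number from compound 3 to compound 4 (0.01 log units; within the scatter) by this estimate, with no clear shift beyond the scatter and more room upward than downward. Compound 4 is expected to give 100000 nM, with an estimated range from 30000 nM to 400000 nM in this read-out.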

Compound 4, half-maximal cytotoxic concentration: 81000 nM
Compound 4: middle estimate off by 1.2-fold (0.09 log units), on the high side, within the range that was stated.
By their numbers in this assay, from the lowest: compounds 1, 4 and 3 (each within the scatter of the next). At a limit, above all of these: compound 2.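

Three different groups on this carbonyl carbon now sit level in this assay: phenoxymethyl in compound 4 matches furan-2-yl, a 1.2-fold lower number from compound 3 to compound 4 (0.08 log units; within the scatter), and it also matches the propyl of compound 1, a 1.6-fold higher number from compound 1 to compound 4 (0.19 log units; within the scatter). Among the four compounds, only the thiophen-2-yl of compound 2 stands apart, and the new comparison shows this again, an at least 20-fold lower number from compound 2 to compound 4 (1.32 log units; beyond the scatter), so an aromatic ring at this place does not by itself separate compounds, as compound 3 and compound 4 go against any such rule. The value of compound 2 is a limit of the assay and not a number: the limit of > 1700000 nM in this assay, at which 1 of the 4 values shown sits.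

As far as these compounds go, how far compound 2 truly lies from the others stays open. Also open, from the compounds shown here alone, is whether thiophen-3-yl, plain phenyl or a chain ending in an amine on this carbonyl carbon would join the level group or follow compound 2.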